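A methyl on the nitrogen-borne phenyl of compound 3

The source may hold more compounds than are shown below. What is called first, only, known or untested is meant among the compounds shown, and "the series" means these compounds.

Of the compounds shown here, three have been measured in a functional assay on MCF7 cells (Homo sapiens) for inhibition, read by MTT assay, with a stated time of 48 h; a higher number here means a weaker inhibitor, a lower number a stronger inhibitor. Compound 1 `COc1cccc(-n2cc(NC(=O)c3cccc(NS(=O)(=O)c4ccccc4)c3)cn2)c1` gives 16700 nM, compound 2 `Cn1cc(NC(=O)c2ccc(NS(=O)(=O)c3ccccc3)cc2)cn1` gives 58700 nM, and compound 3 `O=C(Nc1cnn(-c2ccccc2)c1)c1ccc(NS(=O)(=O)c2ccccc2)cc1` gives 17100 nM. Within the data shown here, compound 3 thus stands second highest of the three numbers: compound 1 sits within the scatter of it, while compound 2 lies beyond the scatter, the only measured step being a 3.4-fold lower number from compound 2 to compound 3 (0.54 log units; beyond the scatter).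

Compound 4 `Cc1ccc(-n2cc(NC(=O)c3ccc(NS(=O)(=O)c4ccccc4)cc3)cn2)cc1` differs from compound 3 by methyl in place of hydrogen on an aromatic carbon. Among the measured compounds shown here, no measured step bears on this change: the one step, from compound 2 to compound 3, concerns what sits on the aromatic nitrogen, not a substituent on the phenyl that now stands there. With nothing in this assay speaking for or against a methyl at that place, no step beyond the scatter is expected, so the estimated change is a 1.1-fold lower number from compound 3 to compound 4 (0.06 log units; within the scatter). Compound 4 is therefore expected to give about 15000 nM in this assay, with a range from 5000 nM to 45000 nM.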

Compound 4, half-maximal inhibitory concentration: 10900 nM
Compound 4: middle estimate off by 1.4-fold (0.14 log units), on the high side; the measured number falls inside the stated range.
By their numbers in this assay, from the lowest: compounds 4, 1 and 3 (each within the scatter of the next); then compound 2.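

In this assay the phenyl on the aromatic nitrogen accepts a methyl, para to a large group, without a step beyond the scatter (a 1.6-fold lower number from compound 3 to compound 4 (0.20 log units; within the scatter)). The full change from the methyl on that nitrogen to 4-methylphenyl does give a step beyond the scatter (a 5.4-fold lower number from compound 2 to compound 4 (0.73 log units; beyond the scatter)), so the difference from compound 2 that appeared with plain phenyl is still there once the methyl is added. No measurement at hand accounts for either step.

From the compounds shown here alone, whether a larger or charged group at that same carbon, such as an amine, a carboxylic acid or a longer chain, would move the number beyond the scatter stays open. So does the question of whether a methyl elsewhere on this phenyl would behave as this one does.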